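Second benzyl on the amide nitrogen of compound 2

The compounds below may be only part of what the source reports. "The series", "measured", "known", "first", "only" and "open" are said of these compounds alone.

Compound 2 `CN(Cc1ccccc1)C(=O)C1CCN(C(=O)c2ccc(S(C)(=O)=O)c([N+](=O)[O-])c2)CC1` carries a methyl and a benzyl on the amide-type nitrogen. In an ADME assay on HepG2 cells (Homo sapiens) for cytotoxicity, read by CellTiter-Glo and ATP content, with a stated time of 72 h (a lower number here means that less compound is needed, a higher number that more compound is needed for the effect), compound 2 reaches only the limit > 27000 nM. Compound 1 `CS(=O)(=O)c1ccc(C(=O)N2CCC(C(=O)N(Cc3ccccc3)c3ccccc3)CC2)cc1[N+](=O)[O-]` in this assay likewise gives only the limit > 27000 nM. The step that the two limits leave unreadable from compound 1 to compound 2 is unreadable because both values sit at the limit of > 27000 nM in this assay, at which 2 of the 2 values shown sit. Compound 3 `CS(=O)(=O)c1ccc(C(=O)N2CCC(C(=O)N(Cc3ccccc3)Cc3ccccc3)CC2)cc1[N+](=O)[O-]` differs from compound 2 by phenyl in place of hydrogen on a saturated chain carbon bound to an amide-type nitrogen. Going by the values given here, no measured step reads the size of such a change, so nothing points in either direction. Compound 3 is expected to stay near the same limit, with an estimated step that the limit leaves unreadable from compound 2 to compound 3. For compound 3 the estimate is 40000 nM, ranging from 15000 nM to 100000 nM.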

Compound 3, half-maximal effective concentration: > 27000 nM
Compound 3: no number, only a limit (the forecaster's own chance of this, stated with the estimate: 85%); the middle value is on the limit's open side.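

No step can be read among compound 1, compound 2 and compound 3, because all three stand at one limit: the limit of > 27000 nM in this assay, at which 3 of the 3 values shown sit.

In this assay the compounds shown leave open how phenyl, methyl and benzyl on the amide-type nitrogen compare.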